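Cytotoxicity notes on an azido-nucleoside series: allyl for hydroxyethyl

The source may hold more compounds than are shown below. What is called first, only, known or untested is meant among the compounds shown, and "the series" means these compounds.

Compound 1 `[N-]=[N+]=N[C@H]1C[C@H](n2cnc3c(NCCO)nc(N)nc32)O[C@@H]1CO` is assessed in an ADME assay on PBMC cells (Homo sapiens) for cytotoxicity, with a stated time of 5 days; a higher number here means a weaker inhibitor, a lower number a stronger inhibitor. For compound 1 the result is only a limit of the assay, > 100000 nM. Compound 2 `[N-]=[N+]=N[C@H]1C[C@H](n2cnc3c(N)nc(F)nc32)O[C@@H]1CO`, which carries a different substitution pattern on the shared core, gives in this assay a measured value of 30100 nM. Of the two values shown, one sits at the limit of > 100000 nM in this assay, at which 1 of the 2 values shown sits; that is where compound 1 stands, so its position is known only as a limit. Compound 3 `C=CCNc1nc(N)nc2c1ncn2[C@H]1C[C@H](N=[N+]=[N-])[C@@H](CO)O1` has not yet been measured in this assay. It differs from compound 1 by vinyl in place of hydroxymethyl on a saturated chain carbon bound to a nitrogen on an aromatic ring. Among the compounds with values here, no step between measured compounds is available to size this change. The step of a number no higher from compound 1 to compound 3 (the limit leaves the size open) is expected to be small, in no direction beyond the usual scatter. Compound 3 is therefore expected to give 100000 nM in this assay, within a range of 30000 nM to 300000 nM, and quite possibly again as a limit rather than a number.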

Compound 3, half-maximal inhibitory concentration: > 100000 nM
Compound 3 gave a limit, no number (the forecaster's own chance of this, stated with the estimate: 65%); the middle value lies on the limit itself.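

Compound 3 gives only a limit in this assay, > 100000 nM. Within the data shown here, compound 1 also stands at a limit, so no step between compound 1 and compound 3 can be read. Left open is whether 2-hydroxyethyl to allyl shifts cytotoxicity at all, since neither compound has a numerical value.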